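The source may report more compounds than this note shows. Statements on the series, on what has been measured and on what is new or still open speak of the compounds shown alone.

Compound 1 `C=Cn1c2ccc([N+](=O)[O-])cc2c(=O)n1Cc1ccccc1`: 160000 nM
Compound 2 `COC(=O)Cn1c2ccc([N+](=O)[O-])cc2c(=O)n1Cc1ccccc1`: 129000 nM
Compound 3 `N#CCn1c2ccc([N+](=O)[O-])cc2c(=O)n1Cc1ccccc1`: > 256000 nM

All three were tested in an ADME assay on L929 cells (Mus musculus) for cytotoxicity, read by resazurin assay, with a stated time of 48 h; a higher number here means that more compound is tolerated, a lower number that less compound is tolerated. Of the two plain numbers, compound 2 gives the lower one, with 129000 nM; its nearest neighbour is compound 1, and the step of a 1.2-fold lower number from compound 1 to compound 2 (0.09 log units; within the scatter) lies within the scatter. The result for compound 3 is a limit of the assay, > 256000 nM, not a number, and it matches (the limit of > 256000 nM in this assay, at which 1 of the 3 values shown sits).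

Compound 4 `NC(=O)CCCn1c2ccc([N+](=O)[O-])cc2c(=O)n1Cc1ccccc1` has not yet been measured in this assay. Relative to compound 2 the change is 2-carbamoylethyl in place of methoxycarbonyl on a saturated chain carbon bound to an aromatic nitrogen; the same difference, cut one bond further out, reads (methoxycarbonyl)methyl to 3-carbamoylpropyl. For the measured compounds named here, only one measured step touches the same place, the exchange that leads to compound 3: an at least 1.9-fold higher number from compound 2 to compound 3 (0.29 log units; that floor lies within the scatter), a floor that sits within the scatter. The step of an at least 1.6-fold higher number from compound 1 to compound 3 (0.20 log units; that floor lies within the scatter) is likewise only a floor within the scatter, and the step of a 1.2-fold lower number from compound 1 to compound 2 (0.09 log units; within the scatter) shows that exchanging the group on the aromatic nitrogen has so far moved this assay little. Going by the values given here, no measured step exceeds the scatter, so the expected step of a 1.2-fold higher number from compound 2 to compound 4 (0.07 log units; within the scatter) is also within it. Compound 4 is therefore estimated at about 150000 nM, with a range from 70000 nM to 320000 nM.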

Compound 4, concentration lethal to 50% of the cells: > 256000 nM
Compound 4 was reported as a limit (the forecaster's own chance of this, stated with the estimate: 25%); at least 1.7-fold (0.23 log units) between middle value and limit.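

In this assay compound 4 gives > 256000 nM, a limit of the assay and not a number, and the second result of this kind: the limit of > 256000 nM in this assay, at which 2 of the 4 values shown sit. The exchange on the saturated chain carbon bound to an aromatic nitrogen gives an at least 1.9-fold higher number from compound 2 to compound 4 (0.29 log units; that floor lies within the scatter), and the exchange on the aromatic nitrogen itself gives an at least 1.6-fold higher number from compound 1 to compound 4 (0.20 log units; that floor lies within the scatter), so neither floor leaves the scatter. What is new is that this position, so far shown with vinyl, (methoxycarbonyl)methyl and cyanomethyl, now also carries 3-carbamoylpropyl, with a hydrogen-bond donor in the entering 2-carbamoylethyl, and the number does not fall; the step between compound 3 and compound 4 cannot be read, since both results are limits.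

As far as these compounds go, how far compound 3 and compound 4 truly differ from compound 1 and compound 2 stays open, as only floors are available for those steps. Also open, from the compounds shown here alone, is whether an amine or a carboxylic acid at the end of the same chain, or a longer chain ending in the amide, would leave the number in this range or bring it down.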